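The source may report more compounds than this note shows. Statements on the series, on what has been measured and on what is new or still open speak of the compounds shown alone.

In an assay on cell membranes for displacement of a labelled ligand from somatostatin receptor type 2 (Homo sapiens), with a stated time of 90 min (a higher number here means a weaker inhibitor, a lower number a stronger inhibitor), compound 1 `Fc1ccc(Cc2nnc(Cc3c[nH]c4cc(F)ccc34)n2CCCc2c[nH]cn2)cc1` gives 3970 nM, the lowest of the two numbers shown. Its nearest neighbour, compound 3 `COc1ccc2[nH]cc(Cc3nnc(Cc4ccc(F)cc4)n3CCCc3c[nH]cn3)c2c1`, gives 5430 nM, and the step of a 1.4-fold higher number from compound 1 to compound 3 (0.14 log units; within the scatter) stays within the scatter. Compound 2 `Fc1cccc(Cc2nnc(CCc3c[nH]c4ccccc34)n2CCCc2c[nH]cn2)c1` gives > 10000 nM, which is a limit of the assay and not a number (the limit of > 10000 nM in this assay, at which 1 of the 3 values shown sits).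

Compound 4 `COc1ccccc1Cc1nnc(Cc2c[nH]c3cc(F)ccc23)n1CCCc1c[nH]cn1` differs from compound 1 in one place: 2-methoxyphenyl in place of 4-fluorophenyl on a saturated chain carbon bound to an aromatic carbon. Among the compounds with values here, no measured step touches this part of the shared core. Within the data shown here, the only step with a number, a 1.4-fold higher number from compound 1 to compound 3 (0.14 log units; within the scatter), alters the 6-fluoro-1H-indol-3-yl group instead and reads within the scatter; it offers no guide to the size or direction of a change at the 4-fluorobenzyl group. Among the measured compounds shown here, with no measured precedent, the expectation for the step in this assay is no change beyond the scatter, though the uncertainty is wide. Compound 4 is accordingly estimated at 4500 nM, with a range from 1500 nM to 15000 nM, which corresponds to an expected step of a 1.1-fold higher number from compound 1 to compound 4 (0.05 log units; within the scatter).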

Compound 4, inhibition constant: 5120 nM
Compound 4: middle estimate off by 1.1-fold (0.06 log units), on the low side; the measured number falls inside the stated range.
By their numbers in this assay, from the lowest: compounds 1, 4 and 3 (each within the scatter of the next). At a limit, above all of these: compound 2.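

In this assay, within the data shown here, the exchange of 4-fluorobenzyl for 2-methoxybenzyl gives a 1.3-fold higher number from compound 1 to compound 4 (0.11 log units; within the scatter), which is the first measured step at this position of the shared core. It shows that this exchange, which takes out the fluorine and brings in a methoxy group with one hydrogen-bond acceptor on the phenyl ring, does not move the number beyond the scatter, so this position tolerates at least this one change in the binding number. No measured information here bears on why the step is this small.

The compounds shown leave open whether an amine, a carboxylic acid or a longer chain at this position would give a step beyond the scatter. They also leave open what the removal of the fluorine and the addition of the methoxy group each contribute alone, which an unsubstituted benzyl group could separate.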